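This account rests on a few compounds, and the source may have more. Where it says the series, first, only, none or still open, it means among the compounds named here.

Measured in a physicochemical assay for solubility, in phosphate buffer, measured as kinetic solubility, at pH 7.4; on this read-out higher numbers stand for higher solubility and lower numbers for lower solubility:
- compound 1 `Cc1ccccc1-c1nc(CN2CCC(C(=O)NCCCN3CCC(C)CC3)CC2)c(C)o1`: > 67 ug/mL
- compound 2 `Cc1ccccc1-c1nc(CN2CCC(C(=O)NCCCN3CCCCC3)CC2)c(C)o1`: > 65 ug/mL
- compound 3 `Cc1ccccc1-c1nc(CN2CCC(C(=O)NCCCN3CC4CCCC(C4)C3)CC2)c(C)o1`: > 71 ug/mL

Compound 3 stands at the limit of > 71 ug/mL in this assay, at which 1 of the 3 values shown sits. This is a limit and not a number, and the other two values in the series are limits as well.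

Compound 4 `Cc1ccccc1-c1nc(CN2CCC(C(=O)NCCN3C[C@H](C)C[C@H](C)C3)CC2)c(C)o1` has not yet been measured. Its difference from compound 3 is a group of 8 heavy atoms (7 carbon, 1 nitrogen; one six-membered non-aromatic ring with 1 hetero atom) in place of a group of 10 heavy atoms (9 carbon, 1 nitrogen; one six-membered non-aromatic ring of carbon only, one six-membered non-aromatic ring with 1 hetero atom), on a saturated chain carbon, two bonds along the chain from an amide-type nitrogen. The entering group is 3,5-dimethylpiperidin-1-yl, on a saturated chain carbon, two bonds along the chain from an amide-type nitrogen.

Within the data shown here, three measured steps bear on this change: a step that the two limits leave unreadable from compound 1 to compound 2, a step that the two limits leave unreadable from compound 1 to compound 3 and a step that the two limits leave unreadable from compound 2 to compound 3. None has a readable size, so none supplies a measured effect to carry over. Among the measured compounds shown here, no measured compound carries its group two bonds along the chain from an amide-type nitrogen.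

No step beyond the usual scatter is therefore expected in this assay, and no direction can be assigned. This expectation rests on compound 3 at > 71 ug/mL, which is a limit. The expected step is an at least 1.0-fold lower number from compound 3 to compound 4 (0.02 log units; that floor lies within the scatter). For compound 4 the estimated value is 67 ug/mL, with an expected range of 45 ug/mL to 75 ug/mL.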

Compound 4, solubility: > 67 ug/mL
Compound 4 was reported as a limit; the forecaster's own chance of this, stated with the estimate: 85%; the middle value lies on the limit itself.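

In this assay compound 4 gives > 67 ug/mL, which is a limit and not a number. With compound 1, compound 2 and compound 3 also reported as limits, none of the steps to compound 4 can be read. The compounds shown leave open how far any value lies past its limit, and whether 3,5-dimethylpiperidin-1-yl changes this read-out at all.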